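The source may report more compounds than this note shows. Statements on the series, on what has been measured and on what is new or still open speak of the compounds shown alone.

Measured so far in a functional assay on Jurkat cells (Homo sapiens); on this read-out higher numbers stand for weaker inhibition and lower numbers for stronger inhibition:
compound 1 `CC(C)[C@H](NC(=O)COc1cccc2ccccc12)C(=O)N[C@@H](CC(=O)O)C(=O)COc1cc(C(F)(F)F)cc(C(F)(F)F)c1` — > 100000 nM
compound 2 `CC(C)[C@H](NC(=O)COc1cccc2ccccc12)C(=O)N[C@@H](CC(=O)O)C(=O)COc1ccc(C(N)=O)cc1` — > 100000 nM
compound 3 `CC(C)[C@H](NC(=O)COc1cccc2ccccc12)C(=O)N[C@@H](CC(=O)O)C(=O)COc1ccc(Oc2ccccc2)cc1` — 12700 nM

The value of compound 1 is a limit of this assay, not a number. The value of compound 2 is likewise a limit, and so compound 2 stands with compound 1 at the weak end of what is shown (the limit of > 100000 nM in this assay, at which 2 of the 3 values shown sit). Compound 3 alone gives a number.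

Compound 4 `CC(C)[C@H](NC(=O)COc1cccc2ccccc12)C(=O)N[C@@H](CC(=O)O)C(=O)COc1ccc(F)c(F)c1` differs from compound 2 in one place (3,4-difluorophenyl in place of 4-carbamoylphenyl on an oxygen on a saturated carbon). Among the compounds with values here, the only measured step on this pattern is an at least 7.8-fold lower number from compound 2 to compound 3 (0.89 log units; beyond the scatter), where another group replaced the carbamoyl. Compound 4 carries fluorines instead, and compound 1, with trifluoromethyl groups, stayed at the limit. The expected step is therefore small, an at least 1.2-fold lower number from compound 2 to compound 4 (0.09 log units; that floor lies within the scatter). Compound 4 is estimated at 80000 nM, between 20000 nM and 300000 nM.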

Compound 4, half-maximal inhibitory concentration: > 100000 nM
Compound 4 was reported as a limit; the forecaster's own chance of this, stated with the estimate: 55%; at least 1.2-fold (0.09 log units) between middle value and limit.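

Compound 4 gives > 100000 nM in this assay, which is a limit and not a number. Within the data shown here, compound 2 also sits at a limit, so no step from compound 2 to compound 4 can be read. On these data alone, whether compound 1, compound 2 and compound 4 differ from one another stays open.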